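The source may hold more compounds than are shown below. What is called first, only, known or untested is meant among the compounds shown, and "the series" means these compounds.

In an ADME assay on HEK-293T cells (Homo sapiens) for cytotoxicity, read by MTT assay, with a stated time of 24 h (on this read-out higher numbers stand for lower toxicity in this test and lower numbers for higher toxicity in this test), compound 1 `FC(F)(F)c1ccc(-c2nn(-c3ccccc3)cc2-c2nc3ccccc3[nH]2)cc1` gives 167000 nM, and compound 3 `O=S(=O)(c1ccccc1)n1c(-c2cn(-c3ccccc3)nc2-c2ccc(C(F)(F)F)cc2)nc2ccccc21` gives 128000 nM. The two cannot be told apart: a 1.3-fold lower number from compound 1 to compound 3 (0.12 log units; within the scatter). Compound 2 `Cc1ccc(C)c(S(=O)(=O)n2c(-c3cn(-c4ccccc4)nc3-c3ccc(F)cc3)nc3ccccc32)c1` gives 54200 nM, so compound 3 stands level with compound 1 within the scatter and clearly above compound 2 on these three values.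

The next compound, compound 4 `Cc1ccc(C)c(S(=O)(=O)n2c(-c3cn(-c4ccccc4)nc3-c3ccc(C(F)(F)F)cc3)nc3ccccc32)c1`, keeps compound 3 unchanged except on the sulfonyl group: 2,5-dimethylphenyl in place of phenyl on a sulfonyl sulfur. Within the data shown here, no measured step covers this change directly. Among the measured compounds shown here, the one step available, a 1.3-fold lower number from compound 1 to compound 3 (0.12 log units; within the scatter), concerns the same aromatic nitrogen but adds the phenylsulfonyl group rather than altering it, and it stays within the scatter. For the measured compounds named here, compound 2 is the only measured compound with the (2,5-dimethylphenyl)sulfonyl group, but it lacks the trifluoromethyl of compound 3, so it offers only indirect evidence. The value of compound 2 at 54200 nM nevertheless suggests a modest move towards lower numbers, and so towards higher toxicity in this test, probably not beyond the scatter. The expected change is a 1.4-fold lower number from compound 3 to compound 4 (0.15 log units; within the scatter). Compound 4 is estimated at 90000 nM, with an expected range of 45000 nM to 170000 nM.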

Compound 4, half-maximal cytotoxic concentration: 223000 nM
Compound 4: the middle estimate sits 2.5-fold (0.39 log units) below what was measured; the whole stated range lies below it.
By their numbers in this assay, from the lowest: compound 2; then compounds 3, 1 and 4 (each within the scatter of the next).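

In this assay, the change on the sulfonyl sulfur now has a direct reading, a 1.7-fold higher number from compound 3 to compound 4 (0.24 log units; within the scatter), so replacing phenyl with 2,5-dimethylphenyl at this position gives no step beyond the scatter. The same holds against the compound with hydrogen on the aromatic nitrogen, a 1.3-fold higher number from compound 1 to compound 4 (0.13 log units; within the scatter), so compound 1 and both of the sulfonyl compounds carrying trifluoromethyl cannot be told apart. Among these compounds, with the (2,5-dimethylphenyl)sulfonyl group held constant, the first step beyond the scatter appears at a different place, a 4.1-fold higher number from compound 2 to compound 4 (0.61 log units; beyond the scatter), where trifluoromethyl stands in place of fluoro on an aromatic carbon, so the sulfonyl group alone does not set compound 2 apart from compound 4.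

The compounds shown leave open whether a methylsulfonyl group, or a phenyl ring bearing an amine or a carboxylic acid, on the sulfonyl sulfur would stay within the scatter, and whether the step from fluoro to trifluoromethyl would recur with plain phenylsulfonyl on the aromatic nitrogen. No measurement offered here accounts for any of these numbers.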